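Removing one chloro: a hydrogen for chlorine

A few compounds are considered here, and "the series" means these few. Any claim that something is new, unique, unknown or untested is made for them only; others in the source may bear on it.

Compound 1 `O=C(CCC(=O)c1ccc(F)cc1)NCCCO`: > 400 mg/kg
Compound 2 `O=C(CCC(=O)c1ccc(Cl)c(Cl)c1)NCCCO`: > 600 mg/kg

In a functional assay on the whole organism with Mus musculus as the target (a higher number here means that more compound is needed for the effect, a lower number that less compound is needed), compound 1 reaches only the limit > 400 mg/kg. Compound 2 likewise gives only the limit > 600 mg/kg in this assay, so neither value is a number, and compound 2 stands at the limit of > 600 mg/kg in this assay, at which 1 of the 2 values shown sits. Compound 3 `O=C(CCC(=O)c1ccc(Cl)cc1)NCCCO` differs from compound 2 by hydrogen in place of chloro on an aromatic carbon. For the measured compounds named here, no step between measured compounds is available here, so the expected change from compound 2 to compound 3 is set at none beyond the scatter, an at least 1.2-fold lower number from compound 2 to compound 3 (0.07 log units; that floor lies within the scatter). Compound 3 is therefore expected to show roughly 500 mg/kg, within 200 mg/kg to 1200 mg/kg, most likely again reported as a limit.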

Compound 3, dose for half-maximal effect: > 300 mg/kg
Compound 3 was reported as a limit (the forecaster's own chance of this, stated with the estimate: 70%); the middle value does not contradict the limit.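

For the compounds shown here, compound 1, compound 2 and compound 3 all stand only as limits in this assay, so no step to compound 3 can be read. The compounds shown leave open what dose any of them needs, and whether swapping chloro, fluoro or hydrogen changes it.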